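Adding a Hydroxy Group to Compound 1

The source may hold more compounds than are shown below. What is called first, only, known or untested is meant among the compounds shown, and "the series" means these compounds.

Measured in a functional assay on UACC-257 cells (Homo sapiens) for inhibition; a lower number here means a stronger inhibitor of growth, a higher number a weaker inhibitor of growth:
Compound 1 `COc1ccc(-n2cnnc2-c2cc(OC)c(OC)c(OC)c2)cc1`: 3980 nM
Compound 2 `COc1cc(-c2nncn2-c2ccc(N(C)C)cc2)cc(OC)c1OC`: 100000 nM

Compound 1 holds the lower of the two numbers, making it the stronger growth inhibitor so far. Compound 3 `COc1ccc(-n2cnnc2-c2cc(OC)c(OC)c(OC)c2)cc1O` keeps the core of compound 1 with one change: hydroxy in place of hydrogen on an aromatic carbon. Within the data shown here, the only measured step bearing on this is a 25-fold higher number from compound 1 to compound 2 (1.40 log units; beyond the scatter), a large move from a change on the same ring. Among the measured compounds shown here, it shows that numbers can shift far here, but it gives no direction for a hydroxy group, and no hydroxy compound has been measured. A tentative move to a lower number in this assay is expected, and the expected step is an 8.0-fold lower number from compound 1 to compound 3 (0.90 log units; beyond the scatter). Compound 3 is estimated at 500 nM, with a range of 40 nM to 5000 nM.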

Compound 3, concentration for 50% growth inhibition: < 100000 nM
Compound 3 ended at the assay's limit; the forecaster's own chance of this, stated with the estimate: 3%; the middle value does not contradict the limit.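

In this assay compound 3 gives < 100000 nM, which is a limit of the assay and not a number. Among these compounds, no step from compound 1 to compound 3 can be read. The compounds shown leave open whether adding the hydroxy group makes growth inhibition stronger or weaker.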